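A few compounds are considered here, and "the series" means these few. Any claim that something is new, unique, unknown or untested is made for them only; others in the source may bear on it.

Compound 3 `CCCCCCCCN(Cc1nnn[nH]1)c1ccccc1` stands highest of the three measured values in a physicochemical assay for acid dissociation, giving 4.83. Compound 2 `COc1ccc(N(Cc2nnn[nH]2)Cc2ccc(Cl)cc2Cl)cc1` gives 4.29, and compound 1 `Fc1ccccc1CN(Cc1nnn[nH]1)c1ccccc1` gives 4.22; both lie below compound 3 by more than the scatter. For the measured compounds named here, the one measured step that bears on compound 4 `Fc1ccc(CN(Cc2nnn[nH]2)c2ccccc2)cc1` is a number 0.61 log units higher from compound 1 to compound 3 (beyond the scatter). Compound 4 differs from compound 3 by 4-fluorophenyl in place of heptyl on a saturated chain carbon bound to a nitrogen on an aromatic ring, which runs that step backwards in kind, a fluorine-bearing phenyl again replacing the heptyl. The step from compound 3 to compound 4 is therefore expected to be a fall of roughly matching size, a number 0.58 log units lower from compound 3 to compound 4 (beyond the scatter), beyond the scatter. Compound 4 is estimated at 4.25, with a range from 4 to 4.5.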

Compound 4, acid dissociation constant: 4.2
Estimate against measurement, compound 4: 0.05 log units above, within the range that was stated.
By their numbers in this assay, from the lowest: compounds 4, 1 and 2 (each within the scatter of the next); then compound 3.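

In this assay, 4-fluorophenyl in place of heptyl gives a number 0.63 log units lower from compound 3 to compound 4 (beyond the scatter) and so shows that a second fluorophenyl group also reads well under the heptyl compound at this position. The step from 2-fluorophenyl to 4-fluorophenyl is a number 0.02 log units lower from compound 1 to compound 4 (within the scatter) and so the place of the fluorine on the phenyl ring does not show in this read-out.

As far as these compounds go, whether cyclohexyl or a shorter chain such as ethyl at this position would read like heptyl or like the fluorophenyl groups stays open. No measured evidence accounts for the gap between heptyl and the fluorophenyl groups.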